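Shrinking the Ring on the Thiocarbonyl Carbon

The source may report more compounds than this note shows. Statements on the series, on what has been measured and on what is new or still open speak of the compounds shown alone.

Measured compounds so far:
compound 1 `Cc1ccnc(/C(N)=N/NC(=S)N2CCSCC2)c1` with 84.9%
compound 2 `N/C(=N\NC(=S)N1CCCC1)c1ccccn1` with 86%
compound 3 `Cc1ccnc(/C(N)=N/NC(=S)N2CCCCC2)c1` with 80%

All three share a thiosemicarbazide-type core carrying a saturated ring on the thiocarbonyl carbon, and all were tested in a functional assay on A-375 cells (Homo sapiens) for cytotoxicity, read by MTT assay, with a stated time of 72 h, tested at 30 uM; a lower number here means less inhibition of growth, a higher number more inhibition of growth at the concentration tested. Compound 3 gives 80% in this assay, which is the smallest of the three numbers, but its gaps to compound 1 and to compound 2 are both within the scatter, so no order among them can be claimed.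

Compound 4 `Cc1ccnc(/C(N)=N/NC(=S)N2CCCC2)c1` has not yet been measured. It differs from compound 3 by one change: pyrrolidin-1-yl in place of piperidin-1-yl on a thiocarbonyl carbon. Going by the values given here, the only measured step that bears on this is the ring exchange on the same carbon, a number 4.9 percentage points lower from compound 1 to compound 3 (within the scatter), which was within the scatter. Compound 2, which carries the pyrrolidin-1-yl ring on its core, gives 86% in this assay, and compound 3 with the piperidin-1-yl ring gives 80%; these two values also lie within the scatter of each other.

Taken together, the ring size on the thiocarbonyl carbon has so far not shifted this assay beyond the scatter, so compound 4 is expected to stay close to compound 3, with an estimated step of a number 4 percentage points higher from compound 3 to compound 4 (within the scatter). The estimate for compound 4 is 84%, with a range from 74% to 92%.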

Compound 4, percent growth inhibition at one concentration: 87.9%
Beside the measured number, compound 4's estimate is 3.9 percentage points below it; low and high end bracket the measured number.
By their numbers in this assay, from the lowest: compounds 3, 1, 2 and 4 (each within the scatter of the next).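

With the methyl-bearing core held constant, compound 4 gives three saturated rings on the thiocarbonyl carbon to compare in this assay: pyrrolidin-1-yl in place of piperidin-1-yl gives a number 7.9 percentage points higher from compound 3 to compound 4 (within the scatter) and pyrrolidin-1-yl in place of thiomorpholin-4-yl gives a number 3 percentage points higher from compound 1 to compound 4 (within the scatter) and so these rings cannot be ranked, whether the ring has five or six members or carries a sulfur atom. Going by these compounds alone, compounds 2 and 4 also provide the first comparison at a different place, the aromatic carbon of the core, where methyl in place of hydrogen gives a number 1.9 percentage points higher from compound 2 to compound 4 (within the scatter) and so this small addition cannot be said to alter growth inhibition at the tested concentration. No supporting measurement is available to explain any of these results.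

Still open, on these data alone, is whether a more different group on the thiocarbonyl carbon, such as an open-chain diethylamino group or a piperazin-1-yl ring with its second ring nitrogen, would produce a step beyond the scatter. As far as these compounds go, it is equally open whether a methoxy group or a chlorine atom on the aromatic carbon would do so in this assay as well.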